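Aniline swap on the shared core: compound 3 to compound 4

The compounds below may be only part of what the source reports. "The series", "measured", "known", "first", "only" and "open" are said of these compounds alone.

In a functional assay on NCI-H1975 cells (Homo sapiens) for inhibition, read by MTT assay, with a stated time of 72 h (a higher number here means a weaker inhibitor, a lower number a stronger inhibitor), compound 3 `C=CC(=O)Nc1cccc(NC(=O)CSc2nc(Nc3ccccc3Cl)c3ccccc3n2)c1` gives 10000 nM. This is indistinguishable within the scatter from compound 1 `O=C(CSc1nc(Nc2ccccc2)c2ccccc2n1)Nc1cccc(Br)c1` at 10100 nM and from compound 2 `O=C(CSc1nc(Nc2ccccc2)c2ccccc2n1)Nc1ccc(C(F)(F)F)cc1` at 11700 nM. Compound 4 `C=CC(=O)Nc1cccc(NC(=O)CSc2nc(Nc3cccc([N+](=O)[O-])c3)c3ccccc3n2)c1` differs from compound 3 by 3-nitrophenyl in place of 2-chlorophenyl on a nitrogen on an aromatic ring. For the measured compounds named here, the only measured step, a 1.2-fold higher number from compound 1 to compound 2 (0.06 log units; within the scatter), changes the aryl group on an amide-type nitrogen, not the aryl group on a nitrogen on an aromatic ring, so it bears on the present change only loosely; no measured pair varies that second position. All three numbers sit close together, so the expectation for compound 4 is a step of no size beyond the scatter, no change at the digits printed from compound 3 to compound 4 (within the scatter). Compound 4 is therefore estimated at 10000 nM, with a range from 4000 nM to 25000 nM.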

Compound 4, half-maximal inhibitory concentration: 22600 nM
Compound 4: the middle estimate sits 2.3-fold (0.35 log units) below what was measured, within the range that was stated.
By their numbers in this assay, from the lowest: compounds 3, 1, 2 and 4 (each within the scatter of the next, the first and the last beyond it).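

In this assay, the aryl group on a nitrogen on an aromatic ring is a position where a change reaches beyond the scatter: 3-nitrophenyl in place of 2-chlorophenyl gives a 2.3-fold higher number from compound 3 to compound 4 (0.35 log units; beyond the scatter), a modest weakening. For the compounds shown here, the only earlier step, on an amide-type nitrogen, stayed within the scatter. Nothing available accounts for this step.

2-chlorophenyl and 3-nitrophenyl differ in both the group and its place on the ring, and the compounds shown do not separate the two. From the compounds shown here alone, how an amine or a carboxylic acid on this phenyl ring would read also stays open.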